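A few compounds are considered here, and "the series" means these few. Any claim that something is new, unique, unknown or untested is made for them only; others in the source may bear on it.

Compound 1 `Nc1ncnc2c1ncn2[C@@H]1O[C@H](CSCC[C@H](N)C(=O)NCC2CC2)[C@@H](O)[C@H]1O` gives 60000 nM
Compound 2 `Cc1ccccc1-n1cc(CNC(=O)[C@@H](N)CCSC[C@H]2O[C@@H](n3cnc4c(N)ncnc43)[C@H](O)[C@@H]2O)cn1` gives 28000 nM
Compound 3 `Cn1nc(CNC(=O)[C@@H](N)CCSC[C@H]2O[C@@H](n3cnc4c(N)ncnc43)[C@H](O)[C@@H]2O)cc1C1CCC1` gives 40000 nM

All three numbers come from an assay on Sf9 cells for inhibition of histone-lysine N-methyltransferase EZH2 (Homo sapiens), read by scintillation counting, in the presence of a further agent that is not named here (on this read-out lower numbers stand for stronger inhibition and higher numbers for weaker inhibition), and all three compounds share the same core, differing only in the group on a saturated chain carbon bound to an amide-type nitrogen. Compound 3 lies between the other two on these numbers, yet its gaps to both neighbours are small: a 1.5-fold lower number from compound 1 to compound 3 (0.18 log units; within the scatter) and a 1.4-fold higher number from compound 2 to compound 3 (0.15 log units; within the scatter). Going by the values given here, the one step that reaches beyond the scatter is a 2.1-fold lower number from compound 1 to compound 2 (0.33 log units; beyond the scatter), and even that is modest. Compound 4 `COCc1cc(CNC(=O)[C@@H](N)CCSC[C@H]2O[C@@H](n3cnc4c(N)ncnc43)[C@H](O)[C@@H]2O)n[nH]1` continues the same kind of change, (a group of 8 heavy atoms (5 carbon, 2 nitrogen, 1 oxygen; one five-membered aromatic ring with 2 hetero atoms) in place of a group of 10 heavy atoms (8 carbon, 2 nitrogen; one four-membered non-aromatic ring of carbon only, one five-membered aromatic ring with 2 hetero atoms), on a saturated chain carbon bound to an amide-type nitrogen). Every measured step at this position moved the number only a little, so the step of a 1.1-fold higher number from compound 3 to compound 4 (0.05 log units; within the scatter) is expected to be small, with no clear direction. Compound 4 is therefore estimated at 45000 nM in this assay, with a range from 20000 nM to 100000 nM.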

Compound 4, half-maximal inhibitory concentration: 40000 nM
Estimate against measurement, compound 4: 1.1-fold (0.05 log units) above; low and high end bracket the measured number.
By their numbers in this assay, from the lowest: compounds 2, 3, 4 and 1 (each within the scatter of the next, the first and the last beyond it).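

In this assay, the incoming 5-(methoxymethyl)-1H-pyrazol-3-yl group has no four-membered ring and brings one hydrogen-bond donor where the group it replaces has none, yet the number stays put (no change at the digits printed from compound 3 to compound 4 (within the scatter)). The new compound also lies within the scatter of both compounds at the ends of the series (a 1.4-fold higher number from compound 2 to compound 4 (0.15 log units; within the scatter); a 1.5-fold lower number from compound 1 to compound 4 (0.18 log units; within the scatter)), although those two are printed as differing beyond it. At this place, then, a group with an added donor and an oxygen in its side chain reads the same as the larger groups with a four-membered or benzene-type ring. From the compounds shown here alone, whether an amine or a carboxylic acid on a saturated chain carbon bound to an amide-type nitrogen would shift the number beyond the scatter stays open. Nothing at hand explains why these changes move the number so little.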